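This account rests on a few compounds, and the source may have more. Where it says the series, first, only, none or still open, it means among the compounds named here.

Of the compounds shown here, three from one series have been measured for agonist activity in an assay on COS-7 cells for agonist activity at Free fatty acid receptor 1 (Homo sapiens), read by scintillation counting and inositol phosphate accumulation, with a stated time of 90 min; on this read-out higher numbers stand for an effect only at larger amounts of compound and lower numbers for an effect already at smaller amounts. Compound 1, `Cc1cc(=O)oc2cc(OCc3nc(N)nc(Nc4ccc(Cl)cc4)n3)ccc12`, gives 32500 nM. Compound 2, `Cc1ccc(Nc2nc(N)nc(COc3ccc4c(C)cc(=O)oc4c3)n2)cc1`, gives 1790 nM. Compound 3, `Cc1ccc(Nc2nc(N)nc(COc3ccc4c(C)cc(=O)oc4c3)n2)cc1Cl`, gives 140 nM, the lowest of the three numbers, with every step to the others beyond the usual scatter.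

Compound 2 and compound 3 differ by chloro in place of hydrogen on an aromatic carbon. That step is a 13-fold lower number from compound 2 to compound 3 (1.11 log units; beyond the scatter). Compound 2 and compound 1 differ by chloro in place of methyl on an aromatic carbon, and that step is an 18-fold higher number from compound 2 to compound 1 (1.26 log units; beyond the scatter). Between compound 1 and compound 3 the change is larger, a 230-fold lower number from compound 1 to compound 3 (2.37 log units; beyond the scatter).

Compound 4, `Cc1cc(=O)oc2cc(OCc3nc(N)nc(Nc4ccc(Cl)c(Cl)c4)n3)ccc12`, has not been measured. It differs from compound 3 by chloro in place of methyl on an aromatic carbon. Within the data shown here, this is the same kind of change as the one from compound 2 to compound 1, but the surroundings of the place are not the same: in compound 3 the carbon that carries the methyl is ortho to a chloro group as well as para to a large group, whereas in compound 2 it is only para to a large group.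

Among the measured compounds shown here, the one measured example of this kind of change, an 18-fold higher number from compound 2 to compound 1 (1.26 log units; beyond the scatter), is the only basis for an expectation. For the measured compounds named here, compound 4 is therefore expected to give a higher number than compound 3 in this assay, by a step of about a 14-fold higher number from compound 3 to compound 4 (1.15 log units; beyond the scatter), since the single precedent rests on compound 2 and compound 1 alone and may not carry over fully to the different surroundings. Compound 4 is estimated at 2000 nM, within a range of 400 nM to 8000 nM.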

Compound 4, half-maximal effective concentration: 780 nM
For compound 4 the middle estimate is 2.6-fold (0.41 log units) above the measured one, and the stated range covers the measured number.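

In this assay, chloro in place of methyl on an aromatic carbon moves the number in the same direction on both cores, but the size does not carry over, the new case being a 5.6-fold higher number from compound 3 to compound 4 (0.75 log units; beyond the scatter) and the comparison with the earlier case being this: the same change on two cores in this assay, an 18-fold higher number (1.26 log units; beyond the scatter) from compound 2 to compound 1 and a 5.6-fold higher number (0.75 log units; beyond the scatter) from compound 3 to compound 4, 3.3-fold (0.51 log units) apart, beyond the scatter of two such steps. Chloro in place of hydrogen on an aromatic carbon also moves the number in one direction on both cores, here a 42-fold lower number from compound 1 to compound 4 (1.62 log units; beyond the scatter) and again by a different amount: the same change on two cores in this assay, a 13-fold lower number (1.11 log units; beyond the scatter) from compound 2 to compound 3 and a 42-fold lower number (1.62 log units; beyond the scatter) from compound 1 to compound 4, 3.3-fold (0.51 log units) apart, beyond the scatter of two such steps. These pairs show that the direction of each change held in the compounds shown, while a 2.3-fold lower number from compound 2 to compound 4 (0.36 log units; beyond the scatter) brings together 3,4-dichlorophenyl in place of 4-methylphenyl in a single step; they give no size that can be carried safely from one core to another, they do not explain the gaps, and with only two pairs for each change they set no rule for the series.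

The compounds shown leave open how a bromo or a methoxy group would compare with methyl and chloro on the same aromatic carbon. They also leave open whether these steps would keep their direction if a carboxylic acid were carried on the shared core.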